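The compounds below may be only part of what the source reports. "The series", "measured", "known", "first", "only" and "open" are said of these compounds alone.

Measured compounds: compound 1 `CC(CNCC1CC1)Oc1cccc2ccc(N)nc12` with 460 nM in a functional assay on IMR-32 cells with melanin-concentrating hormone receptor 1 (Homo sapiens) as the target, read by fluorescence; on this read-out higher numbers stand for weaker inhibition and lower numbers for stronger inhibition; compound 2 `CC(CNCC1CCCC1)Oc1cccc2ccc(N)nc12` with 100 nM in this assay.

Compound 2 holds the lowest of the two numbers. Compound 3 `CC(CNC1CC1)Oc1cccc2ccc(N)nc12` is not yet measured; it carries cyclopropyl in place of cyclopentylmethyl on an amine nitrogen. For the measured compounds named here, the one measured step that bears on this, a 4.6-fold lower number from compound 1 to compound 2 (0.66 log units; beyond the scatter), runs the other way, a ring enlargement on the chain carbon bound to the amine nitrogen. Removing that larger ring, and the chain carbon with it, is expected to undo most of that gain, so a modest rise in this assay is expected, a 6.0-fold higher number from compound 2 to compound 3 (0.78 log units; beyond the scatter). Compound 3 is therefore estimated at 600 nM, within 200 nM to 2000 nM.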

Compound 3, half-maximal inhibitory concentration: 580 nM
For compound 3 the middle estimate is 1.0-fold (0.01 log units) above the measured one; measured number inside the range.
By their numbers in this assay, from the lowest: compound 2; then compounds 1 and 3 (each within the scatter of the next).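

In this assay, removing the chain carbon while keeping the cyclopropyl ring on the amine nitrogen gives a 1.3-fold higher number from compound 1 to compound 3 (0.10 log units; within the scatter), so with this small ring that carbon makes no readable difference. Replacing cyclopentylmethyl with cyclopropyl gives a 5.8-fold higher number from compound 2 to compound 3 (0.76 log units; beyond the scatter), which shows that among these three compounds only the one with the cyclopentyl ring stands apart. Nothing at hand explains these values. As far as these compounds go, it remains open whether cyclopentyl bound directly to the amine nitrogen would keep the lower number of compound 2, and how cyclobutylmethyl or cyclohexylmethyl would compare.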